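A few compounds are considered here, and "the series" means these few. Any claim that something is new, unique, unknown or untested is made for them only; others in the source may bear on it.

Measured so far in a functional assay on MCF7 cells (Homo sapiens) for inhibition, read by MTT assay, with a stated time of 48 h; a lower number here means a stronger inhibitor, a higher number a weaker inhibitor:
compound 1, `O=C(C=CNc1cc(-c2ccccc2)nn1-c1ccccc1)c1ccc(Cl)cc1`, gives 8070 nM;
compound 2, `COc1ccc(-c2nc3c(c(-c4ccccc4)nn3-c3ccccc3)c(-c3ccc(N4CCCCC4)cc3)c2C#N)cc1`, gives 2760 nM;
compound 3, `CN1CCN(c2ccc(-c3c(C#N)c(-c4ccc(Cl)cc4)nc4c3c(-c3ccccc3)nn4-c3ccccc3)cc2)CC1`, gives 2710 nM.

Compound 1 has the highest number of the three. Compound 2 and compound 3 both sit lower, and each gap to compound 1 is beyond the scatter. Compound 4, `O=C(C=CNc1cc(-c2ccccc2)nn1-c1ccccc1)c1ccc(Br)cc1`, is not yet measured and differs from compound 1 in one place: bromo in place of chloro on an aromatic carbon. Within the data shown here, no measured pair shows this change, so nothing in the numbers fixes its size or direction. In this assay a step of about a 1.1-fold lower number from compound 1 to compound 4 (0.03 log units; within the scatter) is expected, inside the scatter and in no fixed direction. Compound 4 is therefore estimated at 7500 nM, with a range from 3500 nM to 16000 nM.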

Compound 4, half-maximal inhibitory concentration: 21700 nM
Compound 4: the middle estimate sits 2.9-fold (0.46 log units) below what was measured; the whole stated range lies below it.
By their numbers in this assay, from the lowest: compounds 3 and 2 (each within the scatter of the next); then compound 1; then compound 4.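

In this assay the halogen on this aromatic carbon is not interchangeable: bromo in place of chloro gives a 2.7-fold higher number from compound 1 to compound 4 (0.43 log units; beyond the scatter) and so a weaker inhibitor. Among these compounds, this is the first single-place step, showing that a change of one heavy atom at this position can move the number beyond the scatter. It rests on one pair, and nothing available explains it.

From the compounds shown here alone, whether fluoro, methyl, methoxy or an amine at this carbon would give a stronger or a weaker inhibitor stays open. Also open, going by these compounds, is whether the same change on the 4-chlorophenyl group of compound 3 would move its number the same way.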